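This account rests on a few compounds, and the source may have more. Where it says the series, first, only, none or still open, it means among the compounds named here.

Measured so far in a functional assay on MDA-MB-231 cells (Homo sapiens) for cytotoxicity, read by MTT assay, with a stated time of 24 h; on this read-out lower numbers stand for stronger inhibition and higher numbers for weaker inhibition:
- compound 1 `Cc1ccc(NS(=O)(=O)c2ccc(-c3ccccc3)cc2)cc1Nc1nccc(-c2cccnc2)n1` gives 8000 nM
- compound 2 `Cc1ccc(NS(=O)(=O)c2cnc3ccccc3c2)cc1Nc1nccc(-c2cccnc2)n1` gives 7310 nM
- compound 3 `COc1cc(-c2ccnc(Nc3cc(NS(=O)(=O)c4ccc(-c5ccccc5)cc4)ccc3C)n2)cc(OC)c1OC` gives 6930 nM

Compound 3 carries the lowest of the three numbers, but its gaps to the other two are small: compound 2 sits nearest, compound 1 furthest, and neither gap reaches beyond the scatter. The two single-point steps behave the same way. The change on the sulfonyl sulfur, a 1.1-fold lower number from compound 1 to compound 2 (0.04 log units; within the scatter), and the change on the aromatic carbon of the core, a 1.2-fold lower number from compound 1 to compound 3 (0.06 log units; within the scatter), both stay within the scatter, so on these three compounds nothing yet separates the series in this assay.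

The next compound, compound 4 `COc1ccc(S(=O)(=O)Nc2ccc(C)c(Nc3nccc(-c4cc(OC)c(OC)c(OC)c4)n3)c2)cc1`, keeps the 3,4,5-trimethoxyphenyl group of compound 3 and alters the group on the sulfonyl sulfur: methoxy in place of phenyl on an aromatic carbon. Among the compounds with values here, no measured step swaps phenyl for methoxy, so the only guidance is indirect. The step that bears on it is the earlier change at the same sulfonyl position, a 1.1-fold lower number from compound 1 to compound 2 (0.04 log units; within the scatter), which did not move the number beyond the scatter. On that precedent, the step of a 1.0-fold higher number from compound 3 to compound 4 (0.00 log units; within the scatter) is expected to fall within the scatter as well, with no direction favoured. Compound 4 is therefore estimated at 7000 nM, with a range from 3000 nM to 16000 nM.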

Compound 4, half-maximal inhibitory concentration: 6860 nM
For compound 4 the middle estimate is 1.0-fold (0.01 log units) above the measured one; the measured number falls inside the stated range.
By their numbers in this assay, from the lowest: compounds 4, 3, 2 and 1 (each within the scatter of the next).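

In this assay, within the data shown here, the step of a 1.0-fold lower number from compound 3 to compound 4 (0.00 log units; within the scatter) is the first direct reading of the outer phenyl: with the 3,4,5-trimethoxyphenyl group held on the core, 4-phenylphenyl gives way to 4-methoxyphenyl, so a six-membered aromatic ring of 6 heavy atoms is replaced by a methoxy of 2 heavy atoms carrying a hydrogen-bond acceptor, and the number stays within the scatter. The earlier change on the sulfonyl sulfur, a 1.1-fold lower number from compound 1 to compound 2 (0.04 log units; within the scatter), was read with pyridin-3-yl on the core, so this group has now been varied with each of the two core substituents without a step beyond the scatter, and no compound shown goes against that. No evidence accompanies these compounds that would account for this result.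

Going by these compounds, it remains open whether an amine or a carboxylic acid in the place of the methoxy, para to the large group, or a longer chain such as butoxy, would give a step beyond the scatter. Also open, on these data alone, are the pairing of 4-methoxyphenyl with pyridin-3-yl on the core and any change to the methyl group of the shared core.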